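The source may report more compounds than this note shows. Statements on the series, on what has been measured and on what is new or still open speak of the compounds shown alone.

In a functional assay on HCT-116 cells (Homo sapiens) for cytotoxicity, read by MTT assay, with a stated time of 72 h (on this read-out lower numbers stand for stronger inhibition and higher numbers for weaker inhibition), three compounds have been measured so far. Compound 1 `CC(C)(C)c1nc2ccccc2n1C(=O)c1cccc2ccccc12` gives only a limit, > 10000 nM. Compound 2 `COc1ccc(-c2nc3ccccc3n2C(=O)c2cccc3ccccc23)cc1` gives a true number, 1700 nM. Compound 3 `COc1ccc(C(=O)n2c(CC(C)C)nc3ccccc32)cc1` gives 3560 nM, the higher of the two true numbers, and the gap to compound 2 at 1700 nM lies just beyond the usual scatter.

Compound 4 `COc1ccc(C(=O)n2c(C(C)C)nc3ccccc32)cc1` differs from compound 3 by having isopropyl in place of isobutyl on an aromatic carbon. Among the compounds with values here, only one measured step bears on this change, and only loosely. The step of an at least 5.8-fold lower number from compound 1 to compound 2 (0.76 log units; beyond the scatter) puts 4-methoxyphenyl in place of tert-butyl on an aromatic carbon, which is a much bigger exchange than the one at issue here. One end of that step is the limit of > 10000 nM in this assay, at which 1 of the 3 values shown sits, so it gives a bound and not a size. Within the data shown here, no measured pair isolates a swap between two small branched chains, so the size of this change remains untested in this assay. On these data alone, no shift beyond the scatter is therefore expected, and the direction stays open. The expected step is a 1.1-fold higher number from compound 3 to compound 4 (0.05 log units; within the scatter). For compound 4 the estimated value is 4000 nM, with an expected range from 1500 nM to 10000 nM.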

Compound 4, half-maximal inhibitory concentration: 190 nM
Beside the measured number, compound 4's estimate is 21-fold (1.32 log units) above it, outside the stated range (below it).
By their numbers in this assay, from the lowest: compound 4; then compound 2; then compound 3. At a limit, above all of these: compound 1.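

In this assay, the position on the aromatic carbon between two ring nitrogen atoms proves highly sensitive to a small change of chain, with isopropyl in place of isobutyl giving a 19-fold lower number from compound 3 to compound 4 (1.27 log units; beyond the scatter). Within the data shown here, this is the first measured pair here to isolate an exchange between two small branched chains: isobutyl, with 4 heavy atoms, gives way to isopropyl, with 3, and neither chain has a ring, a hydrogen-bond donor, a hydrogen-bond acceptor or a net charge, so a large step in this assay does not require a large change in these counted features. The value of compound 1 remains a limit rather than a number, so it cannot show how the tert-butyl group ranks against these two chains: the limit of > 10000 nM in this assay, at which 1 of the 4 values shown sits.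

The compounds shown leave open whether the step follows the branching of the chain or its length, a question that an ethyl, a straight propyl or a cyclopropyl group at this position on the shared core of compound 3 and compound 4 would address. They also leave open whether the same exchange would have a similar effect on the core of compound 2.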